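The source may hold more compounds than are shown below. What is called first, only, known or untested is meant among the compounds shown, and "the series" means these compounds.

Compound 1 (`O=C(CCCCC(S)CCS)Nc1ccc(F)cc1`): 6.78%
Compound 2 (`O=C(CCCCC(S)CCS)Nc1ccc([N+](=O)[O-])c(C(F)(F)F)c1`): "not active" (no number reported)

Both results come from a functional assay on KB cells (Homo sapiens) for inhibition, read by MTT assay, with a stated time of 24 h, tested at 0.1 ug/mL (a lower number here means less inhibition of growth, a higher number more inhibition of growth at the concentration tested), and the two compounds differ in the groups on their aromatic ring. Compound 2 has no single number, since compound 2 is recorded only as "not active" (no number reported) in this test. No measured gap therefore separates it from compound 1.

Compound 3 (`O=C(CCCCC(S)CCS)Nc1ccc([N+](=O)[O-])cc1`) has not yet been measured. The structural change is hydrogen in place of trifluoromethyl on an aromatic carbon and it amounts to hydrogen in place of trifluoromethyl on an aromatic carbon, while the nitro group stays. For the measured compounds named here, no measured pair shows how much such a swap matters in this assay so any forecast rests on thin evidence. Going by the values given here, the only number available is compound 1 at 6.78% and that sits low on the scale. I therefore expect compound 3 to stay close to where compound 2 stands, with no step beyond the usual scatter, and a report of no activity would not be surprising. For compound 3 the estimated growth inhibition is 5% with an expected range from 0% to 15% at its upper end.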

Compound 3, percent growth inhibition at one concentration: "not active" (no number reported)
Compound 3: no number reported; there is nothing to compare the estimate with.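

Compound 2 and compound 3 are each recorded only as not active, with no number, in this assay, and no step can be read between them. No measured evidence bears on this result. Still open, on these data alone, is whether hydrogen in place of trifluoromethyl changes growth inhibition by any amount.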